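A few compounds are considered here, and "the series" means these few. Any claim that something is new, unique, unknown or untested is made for them only; others in the source may bear on it.

The three measured compounds share one core and differ only in the group attached to the ester. In an ADME assay on a cell-free system (plasma, Rattus norvegicus) for pharmacokinetics (on this read-out lower numbers stand for a shorter-lived compound and higher numbers for a longer-lived compound), compound 1 `CCOC(=O)/C=C/c1ccc(NC(=O)C2(NC(=O)c3ccc4c(C5CCCC5)c(-c5ncc(Cl)cn5)n(C)c4c3)CCC2)cc1OCC` gives 8.18 h. Compound 2 `CCCOC(=O)/C=C/c1ccc(NC(=O)C2(NC(=O)c3ccc4c(C5CCCC5)c(-c5ncc(Cl)cn5)n(C)c4c3)CCC2)cc1OCC` gives 15.3 h in this assay, and compound 3 `CCOc1cc(NC(=O)C2(NC(=O)c3ccc4c(C5CCCC5)c(-c5ncc(Cl)cn5)n(C)c4c3)CCC2)ccc1/C=C/C(=O)OCC(C)C` gives 18 h. Among the measured compounds shown here, on these numbers compound 2 holds the middle place, yet the step of a 1.9-fold higher number from compound 1 to compound 2 (0.27 log units; within the scatter) and the step of a 1.2-fold higher number from compound 2 to compound 3 (0.07 log units; within the scatter) both lie within the scatter, so only the step of a 2.2-fold higher number from compound 1 to compound 3 (0.34 log units; beyond the scatter) separates any two of them with confidence. Compound 4 `CCOc1cc(NC(=O)C2(NC(=O)c3ccc4c(C5CCCC5)c(-c5ncc(Cl)cn5)n(C)c4c3)CCC2)ccc1/C=C/C(=O)OCC(=O)N1CCOCC1` arises from compound 2 by the change ((morpholin-4-yl)carbonyl in place of ethyl on a saturated chain carbon bound to an oxygen next to a carbonyl group). The measured steps all concern small growth of the same chain and point, if anything, gently upward; none involves a group of the kind that enters here, so they bear only loosely on the new step. A change of a 1.1-fold lower number from compound 2 to compound 4 (0.04 log units; within the scatter) is therefore expected, with a wide range to reflect that uncertainty. Compound 4 is estimated to give 14 h in this assay, between 5 h and 40 h.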

Compound 4, half-life: 1.83 h
Estimate against measurement, compound 4: 7.7-fold (0.88 log units) above, outside the stated range (below it).
By their numbers in this assay, from the lowest: compound 4; then compounds 1, 2 and 3 (each within the scatter of the next, the first and the last beyond it).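

At this position, the saturated chain carbon bound to an oxygen next to a carbonyl group, the half-life can fall sharply, which the small alkyl changes did not reveal. In this assay, entry of (morpholin-4-yl)carbonyl gives an 8.4-fold lower number from compound 2 to compound 4 (0.92 log units; beyond the scatter) and also a 9.8-fold lower number from compound 3 to compound 4 (0.99 log units; beyond the scatter) as well as a 4.5-fold lower number from compound 1 to compound 4 (0.65 log units; beyond the scatter) in the same direction. Among the compounds shown here, all three steps lie beyond the scatter, so compound 4 is the shortest-lived of the four, while the only step beyond the scatter among the alkyl esters pointed upward.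

No measurement at hand explains this fall. The compounds shown do not separate the part played by the morpholine ring from that of its carbonyl, and a dimethylamide or a carboxylic acid on this carbon remains an open case.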